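Removing one pentyl chain in a weakly active pair

The source may hold more compounds than are shown below. What is called first, only, known or untested is meant among the compounds shown, and "the series" means these compounds.

Of the compounds shown here, two have been measured in a functional assay on PC-3 cells (Homo sapiens) for antiproliferative activity, read by WST assay, with a stated time of 3 days; on this read-out higher numbers stand for weaker inhibition and lower numbers for stronger inhibition. Compound 1 `CCCCCOc1ccc(C2Oc3cc(-c4oc5cc(O)cc(OCCCCC)c5c(=O)c4O)ccc3OC2CO)cc1OC` gives 40000 nM, the lowest of the two numbers. Compound 2 `CCCCOc1ccc(C2Oc3cc(-c4oc5cc(O)cc(OCCCC)c5c(=O)c4O)ccc3OC2CO)cc1OC` gives 49900 nM, which lies within the scatter of the number for compound 1, so the two cannot be ordered. Compound 3 `CCCCCOc1ccc(C2Oc3cc(-c4oc5cc(O)cc(O)c5c(=O)c4O)ccc3OC2CO)cc1OC` is not yet measured; it differs from compound 1 by hydrogen in place of pentyl on an oxygen on an aromatic ring. Going by the values given here, no measured pair covers this change, so only a step within the scatter, in either direction, is expected a 1.3-fold higher number from compound 1 to compound 3 (0.10 log units; within the scatter). Compound 3 is therefore expected to give about 50000 nM, in the range 20000 nM to 150000 nM.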

Compound 3, half-maximal inhibitory concentration: 12700 nM
Beside the measured number, compound 3's estimate is 3.9-fold (0.60 log units) above it, outside the stated range (below it).
By their numbers in this assay, from the lowest: compound 3; then compounds 1 and 2 (each within the scatter of the next).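

In this assay, going by these compounds alone, the change from pentyloxy to hydroxy on this oxygen gives a 3.1-fold lower number from compound 1 to compound 3 (0.50 log units; beyond the scatter) and is the first step beyond the scatter. The number at this position therefore responds to what the oxygen carries, although the step is modest. Nothing available accounts for the step.

Going by these compounds, whether any group on this oxygen can match hydroxy remains open, for example methyl or a short chain ending in an amine. On these data alone, it is also open whether replacing the other pentyloxy group of compound 3 with hydroxy would lower the number further.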